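Thiophen-3-yl for thiophen-2-yl on two related cores

This account rests on a few compounds, and the source may have more. Where it says the series, first, only, none or still open, it means among the compounds named here.

Measured so far, in an assay on isolated protein for inhibition of DNA topoisomerase 1 (Homo sapiens), with a stated time of 30 min, tested at 20 uM; a lower number here means a weaker effect, a higher number a stronger effect of the compound at the concentration tested:
- compound 1, `Oc1cccc(-c2cc(-c3ccccc3)cc(-c3cccs3)n2)c1`: compound 1 gives 5.8%
- compound 2, `Oc1cccc(-c2cc(-c3ccccc3)cc(-c3ccsc3)n2)c1`: compound 2 gives 6.8%
- compound 3, `Oc1cccc(-c2cc(-c3ccccc3)nc(-c3cccs3)c2)c1`: compound 3 gives 2%

All three numbers sit at the low end of the read-out, and none of the gaps between them goes beyond the usual scatter. Compound 1 and compound 2 share one core and differ by a single change, (thiophen-3-yl in place of thiophen-2-yl on an aromatic carbon); the step it made in this assay is a number 1 percentage points higher from compound 1 to compound 2 (within the scatter), so the swap of the two thiophene isomers left the inhibition essentially where it was. Compound 3 has a different core from compound 1; how the two cores differ is not broken down here, and the only thing to say of the pair is that the two values are within the scatter of each other.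

Compound 4, `Oc1cccc(-c2cc(-c3ccccc3)nc(-c3ccsc3)c2)c1`, has not yet been measured. It stands to compound 3 as compound 2 stands to compound 1: the change is thiophen-3-yl in place of thiophen-2-yl on an aromatic carbon, the same change as before, made at a place described in the same words on both cores. Given that the one measured instance of this change, the step from compound 1 to compound 2, stayed within the scatter, the expected step from compound 3 to compound 4 in this assay is also small, about a number 1 percentage points higher from compound 3 to compound 4 (within the scatter). Compound 4 is therefore estimated at 3%, with a likely range from -5% to 12%, resting on the value of compound 3 and the size of the step from compound 1 to compound 2.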

Compound 4, a percentage reported as inhibition, at one concentration (the size of the read-out at that concentration, not a potency): 3.2%
Compound 4: middle estimate off by 0.2 percentage points, on the low side; measured number inside the range.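

On the core of compound 3, thiophen-3-yl in place of thiophen-2-yl on the aromatic carbon next to the ring nitrogen gives, in this assay, a number 1.2 percentage points higher from compound 3 to compound 4 (within the scatter). Set beside the earlier step, the change reads the same on both cores: the same change on two cores in this assay, a number 1 percentage points higher (within the scatter) from compound 1 to compound 2 and a number 1.2 percentage points higher (within the scatter) from compound 3 to compound 4, 0.2 percentage points apart, within the scatter of two such steps This shows that, for these two pairs, the thiophene swap carries from one core to the other without a step that can be told from the scatter, but all four numbers sit at the low end of the read-out at one concentration, so it does not show that the change would stay as silent on a compound with clearly stronger inhibition, nor does it give a potency for any of them.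

The compounds shown vary only the thiophene isomer and the core, while the phenyl group and the 3-hydroxyphenyl group stay throughout, so it remains open whether any change in this series moves the read-out beyond the scatter. A basic amine on a short alkyl chain, a carboxylic acid in place of the hydroxyl, or a furan-2-yl in place of the thiophene would each test a different part of these structures.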